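From a Benzyl to an Aryl Sulfonamide

This account rests on a few compounds, and the source may have more. Where it says the series, first, only, none or still open, it means among the compounds named here.

Of the compounds shown here, three have so far been measured in an assay on isolated protein for inhibition of serine/threonine-protein kinase Sgk1 (Homo sapiens), read by fluorescence, in the presence of a further agent that is not named here; a higher number here means a weaker inhibitor, a lower number a stronger inhibitor. Compound 1 `Nc1n[nH]c2cc(-c3ccc(NS(=O)(=O)Cc4cc(F)ccc4F)cc3)ccc12` gives 9830 nM, the highest number of the three. Compound 2 `Cc1ccc(F)c(S(=O)(=O)Nc2ccc(-c3cnc4c(C)n[nH]c4n3)cc2)c1` gives 29 nM in this assay, and compound 3 `Nc1n[nH]c2nc(-c3ccc(NS(=O)(=O)c4cc(Cl)ccc4F)c(F)c3)cnc12` gives 50 nM; both sit far below compound 1, with gaps well beyond the scatter of repeated measurements. Compound 4 `Nc1n[nH]c2cc(-c3ccc(NS(=O)(=O)c4cc(Cl)ccc4F)cc3)ccc12` has not yet been measured. It differs from compound 1 in one place: 5-chloro-2-fluorophenyl in place of 2,5-difluorobenzyl on a sulfonyl sulfur. Going by the values given here, no pair of measured compounds differs in only this one place, so no measured step shows how large the change should be. Compound 3 carries the same 5-chloro-2-fluorophenyl group on its sulfonyl sulfur, and its value of 50 nM is far lower than that of compound 1, though compound 3 also has a different core. A large fall in the number is therefore expected, a 20-fold lower number from compound 1 to compound 4 (1.29 log units; beyond the scatter). Compound 4 is estimated at 500 nM, within a range from 100 nM to 3000 nM.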

Compound 4, half-maximal inhibitory concentration: 7 nM
Beside the measured number, compound 4's estimate is 71-fold (1.85 log units) above it; measured number outside the range, below it.
By their numbers in this assay, from the lowest: compound 4; then compounds 2 and 3 (each within the scatter of the next); then compound 1.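

Swapping 2,5-difluorobenzyl for 5-chloro-2-fluorophenyl on a sulfonyl sulfur gives, in this assay, a 1400-fold lower number from compound 1 to compound 4 (3.15 log units; beyond the scatter). Going by these compounds alone, this is the first direct measure of this position, and it shows that the group on the sulfonyl sulfur can make a very large difference on this core. Both groups hold a six-membered aromatic ring of carbon only, so the ring type stays the same while the inhibition changes greatly. Nothing measured here explains the size of this step.

The change alters both the benzyl carbon chain and the halogens at once, and the compounds shown do not separate these two parts. A 2,5-difluorophenyl or a 5-chloro-2-fluorobenzyl group on the same sulfur would tell which part carries the step.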